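The source may report more compounds than this note shows. Statements on the series, on what has been measured and on what is new or still open speak of the compounds shown alone.

Measured in a functional assay on Hep cells (Homo sapiens) for cytotoxicity, read by sulforhodamine B assay, with a stated time of 48 h; on this read-out lower numbers stand for stronger inhibition and higher numbers for weaker inhibition:
- compound 1 `O=C(c1cccnc1)c1cc(Cl)cc(Cl)c1O`: 27000 nM
- compound 2 `O=C(c1cccnc1)c1cc(Cl)ccc1O`: 27000 nM
- compound 3 `C=CCOc1c(Cl)cc(Cl)cc1C(=O)c1cccnc1`: > 100000 nM, a limit of the assay

Compound 2 gives 27000 nM, level with compound 1. Compound 4 `O=C(c1cccnc1)c1cc(Br)ccc1O` is compound 2 with bromo in place of chloro on an aromatic carbon. Among the compounds with values here, the closest precedent is no change at the digits printed from compound 1 to compound 2 (within the scatter), which also exchanges a chloro on an aromatic carbon. The other measured change, an at least 3.7-fold higher number from compound 1 to compound 3 (0.56 log units; beyond the scatter), acts on the oxygen and bears little on this exchange. No step beyond the scatter is therefore expected in this assay. The expected change is a 1.1-fold lower number from compound 2 to compound 4 (0.03 log units; within the scatter). For compound 4 the estimated value is 25000 nM, with an expected range of 11000 nM to 55000 nM.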

Compound 4, half-maximal inhibitory concentration: 29000 nM
Compound 4: middle estimate off by 1.2-fold (0.06 log units), on the low side; measured number inside the range.
By their numbers in this assay, from the lowest: compounds 1, 2 and 4 (each within the scatter of the next). At a limit, above all of these: compound 3.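

Within the data shown here, compounds 1, 2 and 3 all carry chloro on the aromatic carbon para to a hydroxy group, so this is the first change read at that place. In this assay, bromo in place of chloro there gives a 1.1-fold higher number from compound 2 to compound 4 (0.03 log units; within the scatter), so these two halogens do not separate on this read-out. Compound 3 is the only compound at a limit, and that limit does not touch this pair: the limit of > 100000 nM in this assay, at which 1 of the 4 values shown sits.

Only halogens are shown at this place. Going by these compounds, whether an amine, a carboxylic acid or a longer chain there would shift the value remains open.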